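Swapping amino for methoxy on a chalcone-pyrazole scaffold

The compounds below may be only part of what the source reports. "The series", "measured", "known", "first", "only" and "open" are said of these compounds alone.

Compound 1 `COc1cc(-c2cc(/C=C/C(=O)c3ccc(N)cc3)[nH]n2)cc(OC)c1OC` carries a trimethoxyphenyl on a pyrazole that is joined through an unsaturated ketone to an aminophenyl group. In a functional assay on RPMI-8226 cells (Homo sapiens) for cytotoxicity, read by sulforhodamine B assay, with a stated time of 48 h, tested at 0.1 uM (a lower number here means a stronger effect, a higher number a weaker effect of the compound at the concentration tested), compound 1 gives 97%. Compound 2 `COc1ccc(-c2cc(/C=C/C(=O)c3ccc(N)cc3)[nH]n2)cc1OC` keeps the same framework with one methoxy fewer, and in this assay compound 2 gives 96%. Within the data shown here, the single known step, a number 1 percentage points lower from compound 1 to compound 2 (within the scatter), came from a hydrogen in place of methoxy on an aromatic carbon, so the two numbers stand together within the usual scatter and neither can be called stronger.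

Compound 3 `COc1ccc(C(=O)/C=C/c2cc(-c3cc(OC)c(OC)c(OC)c3)n[nH]2)cc1` differs from compound 1 in one place: methoxy in place of amino on an aromatic carbon. Among the measured compounds shown here, no measured step concerns this change; the only step on record, between compound 1 and compound 2, altered a different position and stayed within the scatter. With nothing in the data pointing to a larger shift, compound 3 is expected to give about 92% in this assay, within 70% to 105%. The expected step, a number 5 percentage points lower from compound 1 to compound 3 (within the scatter), would itself fall within the scatter.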

Compound 3, a percentage reported as activity, at one concentration (the size of the read-out at that concentration, not a potency): 90%
The estimate for compound 3 lay 2 percentage points above the measured number, within the range that was stated.
By their numbers in this assay, from the lowest: compounds 3, 2 and 1 (each within the scatter of the next).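

Among these compounds, this result is the first look at the place para to a large group, since the earlier pair changed a different position. In this assay, going from 4-aminophenyl to 4-methoxyphenyl gives a number 7 percentage points lower from compound 1 to compound 3 (within the scatter) and so leaves compounds 1 and 3 without an order, even though the change takes away the hydrogen-bond donor of the amino group and adds a larger group in its place. At the one concentration tested, that donor is therefore not shown to be needed for the reading, and no measured evidence is available to explain the outcome.

The compounds shown leave open whether a hydroxy group, a dimethylamino group, a carboxylic acid or a longer chain such as ethoxy at this place would move the reading beyond the scatter. They also leave open whether the same swap from amino to methoxy would stay within the scatter on the core of compound 2, which has one methoxy fewer on its other aromatic ring.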